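Cyclobutyl for Ethyl on the Amide of Compound 1

The compounds below may be only part of what the source reports. "The series", "measured", "known", "first", "only" and "open" are said of these compounds alone.

Measured compounds:
compound 1 `CCC(=O)N1CCN(Cc2nc3ccccc3n2Cc2cccc(C)c2)CC1` — 85.1%
compound 2 `Cc1cccc(Cn2c(OC3CCN(C(=O)c4ccco4)CC3)nc3ccccc32)c1` — 68.3%

Both compounds were tested in an assay on isolated protein for inhibition of aldehyde dehydrogenase 1A1 (Homo sapiens), read by spectrophotometry, tested at 10 uM; a lower number here means less inhibition, a higher number more inhibition at the concentration tested (going by the name of the read-out). Compound 1 stands highest of the two numbers; its nearest neighbour, compound 2, sits lower by a gap that lies beyond the usual scatter. For the measured compounds named here, the two measured compounds differ in more than one place, so no single step between them can be read from their values; all that the pair shows is that compound 1 gives the larger inhibition.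

Compound 3 `Cc1cccc(Cn2c(CN3CCN(C(=O)C4CCC4)CC3)nc3ccccc32)c1` has not yet been measured. It differs from compound 1 in one place: cyclobutyl in place of ethyl on a carbonyl carbon. Going by the values given here, no measured pair shows a change of this kind, so the size of the step cannot be drawn from the data; it can only be judged against the reading of compound 1, which gives 85.1% in this assay. The step of a number 5.1 percentage points lower from compound 1 to compound 3 (within the scatter) is expected to be small, none beyond the scatter, with a slight downward lean. Compound 3 is therefore estimated at 80%, with a range from 62% to 94%.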

Compound 3, a percentage reported as inhibition, at one concentration (the size of the read-out at that concentration, not a potency): 69.1%
Beside the measured number, compound 3's estimate is 10.9 percentage points above it; low and high end bracket the measured number.
By their numbers in this assay, from the lowest: compounds 2 and 3 (each within the scatter of the next); then compound 1.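

In this assay, for the compounds shown here, the exchange of ethyl for cyclobutyl on a carbonyl carbon gives a number 16 percentage points lower from compound 1 to compound 3 (beyond the scatter) and this is the first change in a single place that can be read, which shows that inhibition responds to the group at this position. The response is partial, as compound 3 still gives 69.1% at the one concentration tested, so the cyclobutyl amide keeps a substantial reading even though it falls short of the propanoyl amide. Nothing measured here accounts for the drop, and no evidence on its cause is available.

The change adds carbon and a four-membered ring at once, so the compounds shown cannot tell whether the ring or the added carbon count goes with the lower reading. Isopropyl or cyclopropyl on the same carbonyl carbon, or a longer chain such as butyl, would separate the two, and whether an amine or a carboxylic acid at this position gives a higher, lower or level number in this assay also stays open.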